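The source may report more compounds than this note shows. Statements on the series, on what has been measured and on what is new or still open speak of the compounds shown alone.

Measured in a functional assay on MGC-803 cells (Homo sapiens) for inhibition, read by MTT assay, with a stated time of 48 h; a higher number here means a weaker inhibitor, a lower number a stronger inhibitor:
Compound 1 `COC(=O)c1cc(CNc2cc(OC)c(OC)c(OC)c2)ccc1OC`: 49600 nM
Compound 2 `COc1ccc(CNc2cc(OC)c(OC)c(OC)c2)cc1F`: 39700 nM
Compound 3 `COc1ccc(CNc2cc(OC)c(OC)c(OC)c2)cc1C`: 56800 nM

Compound 3, at 56800 nM, lies within the scatter of both other compounds, so the three values cannot be ranked. Compound 4 `COc1ccc(CNc2cc(OC)c(OC)c(OC)c2)cc1N` keeps the core of compound 3 and makes a single change: amino in place of methyl on an aromatic carbon. The measured steps that bear on this change swap groups at the same place on the ring. They are a 1.4-fold higher number from compound 2 to compound 3 (0.16 log units; within the scatter), a 1.1-fold higher number from compound 1 to compound 3 (0.06 log units; within the scatter) and a 1.2-fold lower number from compound 1 to compound 2 (0.10 log units; within the scatter). All three lie within the scatter, so methoxycarbonyl, fluoro and methyl have given no separable difference in this assay, and none of these compounds goes against that reading. For the measured compounds named here, the reading covers only these three groups, however, and the data hold no measured amino example, so the steps guide the expectation only loosely. No step beyond the scatter is expected as the central case, with the likely direction towards a somewhat lower number. The expected change is a 1.9-fold lower number from compound 3 to compound 4 (0.28 log units; within the scatter). As far as these compounds go, the range is kept wider on the lower side, as the new group is untested. For compound 4 the estimated value is 30000 nM, with an expected range from 5000 nM to 70000 nM.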

Compound 4, half-maximal inhibitory concentration: 7970 nM
The estimate for compound 4 lay 3.8-fold (0.58 log units) above the measured number, and the stated range covers the measured number.
By their numbers in this assay, from the lowest: compound 4; then compounds 2, 1 and 3 (each within the scatter of the next).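

In this assay the place ortho to a methoxy group had so far shown no separable difference among methoxycarbonyl, fluoro and methyl, but amino separates from all three, with a 7.1-fold lower number from compound 3 to compound 4 (0.85 log units; beyond the scatter) and a 5.0-fold lower number from compound 2 to compound 4 (0.70 log units; beyond the scatter) and a 6.2-fold lower number from compound 1 to compound 4 (0.79 log units; beyond the scatter) as the steps. The position is therefore not indifferent to its group, and among these four compounds only compound 4 stands apart from the rest, while the swap of methyl for amino leaves the heavy-atom count unchanged and adds a hydrogen-bond donor and a hydrogen-bond acceptor. No measurement shown here explains why this one group separates from the others.

As far as these compounds go, it remains open whether the step belongs to amino alone or would also appear with a hydroxyl group, a methylamino group or an acetamide at the same place. From the compounds shown here alone, it is equally open whether amino would give a step of similar size if the methoxy group it sits ortho to, or another part of the shared core, were replaced by a different group such as an ethoxy group.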